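Cytotoxicity of a Carbamoyl Analogue: An Expected Modest Shift

This account rests on a few compounds, and the source may have more. Where it says the series, first, only, none or still open, it means among the compounds named here.

Measured in an ADME assay on L6 cells (Rattus norvegicus) for cytotoxicity, read by resazurin assay, with a stated time of 72 h; on this read-out higher numbers stand for weaker inhibition and lower numbers for stronger inhibition:
Compound 1 `OC(c1ccc(Cl)cc1)(c1ccc(Br)cc1)c1cccnc1` gives 57000 nM
Compound 2 `OC(c1ccc(Cl)cc1)(c1ncccn1)c1ccccc1Cl` gives only a limit, > 100000 nM
Compound 3 `OC(c1ccc(Br)cc1)(c1ccc(C(F)(F)F)cc1)c1cccnc1` gives 54700 nM

Only compound 1 and compound 3 have exact numbers. Putting trifluoromethyl in place of chloro on an aromatic carbon gives a 1.0-fold lower number from compound 1 to compound 3 (0.02 log units; within the scatter), so the two values stand level. Compound 3 therefore shares its place with compound 1 among the exact results. For compound 2, the result is the limit of > 100000 nM in this assay, at which 1 of the 3 values shown sits, which is a limit rather than a number.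

Compound 4 `NC(=O)c1ccc(C(O)(c2ccc(C(F)(F)F)cc2)c2cccnc2)cc1` carries carbamoyl in place of bromo on an aromatic carbon, para to a large group: carbamoyl in place of bromo on an aromatic carbon. The same change can be read as 4-bromophenyl to 4-carbamoylphenyl. For the measured compounds named here, only one measured step bears on this, and it is only a loose guide, since it neither removes bromo nor introduces carbamoyl. That step, a 1.0-fold lower number from compound 1 to compound 3 (0.02 log units; within the scatter), suggests that this series can tolerate a substituent swap without a large change. A modest move towards a higher number, meaning weaker inhibition, therefore seems more likely than a large one in this assay. The expected size of the change is a 1.4-fold higher number from compound 3 to compound 4 (0.14 log units; within the scatter). For compound 4, the estimated value is 75000 nM, with an expected range from 35000 nM to 100000 nM.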

Compound 4, half-maximal inhibitory concentration: > 100000 nM
Compound 4 ended at the assay's limit (the forecaster's own chance of this, stated with the estimate: 35%); middle value at least 1.3-fold (0.12 log units) from the limit.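

In this assay, putting carbamoyl in place of bromo on this aromatic carbon gives an at least 1.8-fold higher number from compound 3 to compound 4 (0.26 log units; that floor lies within the scatter). The floor of that step lies within the scatter, so this pair shows no firm separation, and the true size of the change stays hidden. What is new is that this position, para to a large group, now has a measured replacement with more heavy atoms than bromo and with a hydrogen-bond donor and acceptor, while compound 4 gives a limit and not an exact number: the limit of > 100000 nM in this assay, at which 2 of the 4 values shown sit.

The compounds shown leave open how far past the limit the true value of compound 4 lies, so this pair cannot settle whether carbamoyl really shifts the reading relative to bromo. They also leave open what a carboxylic acid, an amine or a nitrile would give in place of bromo at this position, and whether any of these would yield an exact number that turns the floor into a measured step.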